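The compounds below may be only part of what the source reports. "The series", "measured", "known", "first", "only" and "open" are said of these compounds alone.

In a functional assay on HT-29 cells (Homo sapiens) for inhibition, read by MTT assay, with a stated time of 48 h (on this read-out lower numbers stand for stronger inhibition and higher numbers for weaker inhibition), compound 1 `COc1ccc(-c2cc(-c3cc(OC)c(OC)c(OC)c3)nc(-c3ccccc3)n2)cc1` gives 4230 nM and compound 2 `COc1cc(-c2cc(-c3cccc4ccccc34)nc(-c3ccccc3)n2)cc(OC)c1OC` gives 4730 nM, so the two stand level within the scatter. Compound 3 `COc1cc(-c2cc(-c3ccc(N)cc3)nc(-c3ccccc3)n2)cc(OC)c1OC` is unmeasured and carries amino in place of methoxy on an aromatic carbon, para to a large group: amino in place of methoxy on an aromatic carbon. For the measured compounds named here, the only measured step, a 1.1-fold higher number from compound 1 to compound 2 (0.05 log units; within the scatter), exchanges the whole 4-methoxyphenyl for naphthalen-1-yl, and no measured step tests amino itself. On that thin evidence, no shift beyond the scatter is expected, with an estimated 1.4-fold lower number from compound 1 to compound 3 (0.15 log units; within the scatter). For compound 3 the expected value is 3000 nM, with an estimated range of 800 nM to 8000 nM.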

Compound 3, half-maximal inhibitory concentration: > 25000 nM
Compound 3 was reported as a limit (the forecaster's own chance of this, stated with the estimate: 5%); at least 8.3-fold (0.92 log units) between middle value and limit.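

In this assay compound 3 stands as a limit and not as a number: the limit of > 25000 nM in this assay, at which 1 of the 3 values shown sits.

This position does not treat all exchanges alike: amino in place of methoxy gives an at least 5.9-fold higher number from compound 1 to compound 3 (0.77 log units; beyond the scatter), and 4-aminophenyl in place of naphthalen-1-yl gives an at least 5.2-fold higher number from compound 2 to compound 3 (0.72 log units; beyond the scatter). The change of one small group, para to a large group, thus moves the read-out beyond the scatter, while the exchange of the whole 4-methoxyphenyl for naphthalen-1-yl stays within it.

Open: whether hydroxy, dimethylamino or acetamido at this place reads like methoxy or like amino. On these data alone, the full size of both steps also stays open.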